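Moving a Nitrile Around the Sulfonyl Aryl Ring

This account rests on a few compounds, and the source may have more. Where it says the series, first, only, none or still open, it means among the compounds named here.

Compound 1 `N#Cc1ccc(S(=O)(=O)[C@H]2CN(S(=O)(=O)c3ccc(Cl)cc3Cl)C[C@@H]2O)cc1`: 9 mL/min/kg
Compound 2 `N#Cc1ccc(S(=O)(=O)[C@H]2CN(S(=O)(=O)c3ccc(Cl)cc3Cl)C[C@@]2(O)CO)cc1`: 25 mL/min/kg
Compound 3 `N#Cc1ccc(S(=O)(=O)[C@H]2CN(S(=O)(=O)c3ccc(Cl)cc3C#N)C[C@@]2(O)CO)cc1`: 82 mL/min/kg

In an ADME assay on the whole organism (Rattus norvegicus, strain Sprague-Dawley) for pharmacokinetics, read by LC-MS, with a stated time of 30 min, at a dose of 1 mg/kg by the intravenous route (on this read-out higher numbers stand for fast clearance and lower numbers for slow clearance), compound 3 gives 82 mL/min/kg, the highest of the three numbers. Compound 4 `N#Cc1ccc(S(=O)(=O)[C@H]2CN(S(=O)(=O)c3ccc(C#N)cc3Cl)C[C@@]2(O)CO)cc1` has the same atoms as compound 3, joined differently: 2-chloro-4-cyanophenyl in place of 4-chloro-2-cyanophenyl on a sulfonyl sulfur. In words, this is 2-chloro-4-cyanophenyl in place of 4-chloro-2-cyanophenyl on a sulfonyl sulfur.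

Going by the values given here, no measured pair shows what such a swap does. The nearest evidence is a 3.3-fold higher number from compound 2 to compound 3 (0.52 log units; beyond the scatter), a modest change beyond the scatter, made by putting cyano in place of chloro on an aromatic carbon. Compound 4 still carries both a chloro and a nitrile, so this step is only a rough guide. With compound 3 at the top of a small set, a modest fall seems likelier than a further rise, and a step larger than that one is not expected. The expected change is a 2.1-fold lower number from compound 3 to compound 4 (0.31 log units; beyond the scatter). For compound 4 the estimated clearance is 40 mL/min/kg, with an expected range of 15 mL/min/kg to 95 mL/min/kg.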

Compound 4, clearance in the Rattus norvegicus assay: 35 mL/min/kg
Estimate against measurement, compound 4: 1.1-fold (0.06 log units) above; the measured number falls inside the stated range.
By their numbers in the Rattus norvegicus assay, from the lowest: compound 1; then compounds 2 and 4 (each within the scatter of the next); then compound 3.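

Compound 3 and compound 4 have the same atoms, joined differently. In the Rattus norvegicus assay the change from 4-chloro-2-cyanophenyl to 2-chloro-4-cyanophenyl gives a 2.3-fold lower number from compound 3 to compound 4 (0.37 log units; beyond the scatter). Placement also decides the outcome of the cyano for chloro exchange in the Rattus norvegicus assay, which gives a 1.4-fold higher number from compound 2 to compound 4 (0.15 log units; within the scatter) at one place but a 3.3-fold higher number from compound 2 to compound 3 (0.52 log units; beyond the scatter) at the other. In a physicochemical assay for solubility, read by chemiluminescence, measured as kinetic solubility (a lower number here means a less soluble compound, a higher number a more soluble compound), compound 3 gives 380000 nM and compound 4 gives 400000 nM. In the physicochemical assay the same swap gives a 1.1-fold higher number from compound 3 to compound 4 (0.02 log units; within the scatter) and so does not separate the two compounds on solubility.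

From the compounds shown here alone, it remains open whether an amine or a carboxylic acid in the place of the nitrile on the 2-chloro-4-cyanophenyl group would keep clearance near that of compound 4. Nothing available explains why clearance depends on where these two groups sit.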